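Shortening the chain of a weak inhibitor at the assay limit

This account rests on a few compounds, and the source may have more. Where it says the series, first, only, none or still open, it means among the compounds named here.

Measured in an ADME assay on HEK293 cells (Homo sapiens) for inhibition, read by MTT assay, with stated times of 18 h and 4 h; a higher number here means a weaker inhibitor, a lower number a stronger inhibitor:
Compound 1 `CCCCCCCCOP(=O)(O)OCCSC(=S)N1CCCC1`: 28300 nM
Compound 2 `CCCCCCCCOP(=O)(O)OCCSC(=S)N1CCCCC1`: 69000 nM
Compound 3 `CCCCCCCCCCOP(=O)(O)OCCSC(=S)N1CCN(C)CC1`: > 100000 nM (a limit of the assay, not a number)

Compound 3 has no exact value, and it stands at the limit of > 100000 nM in this assay, at which 1 of the 3 values shown sits. Compound 4 `CCCCCCCCOP(=O)(O)OCCSC(=S)N1CCN(C)CC1` differs from compound 3 in its chain: hydrogen in place of ethyl on a saturated chain carbon, eight bonds along the chain from an oxygen on an unsaturated carbon. Among the compounds with values here, no measured step makes this change, so its size in this assay is unknown. Within the data shown here, the one measured step, a 2.4-fold higher number from compound 1 to compound 2 (0.39 log units; beyond the scatter), alters a different part of the molecule. Among the measured compounds shown here, it shows only that a structural change in this set can shift the number modestly. Compound 4 keeps the end group of compound 3 but shares its chain with compound 2, which gives 69000 nM. A modest step at most therefore seems likely, towards a lower number if there is any clear change. The expected step is an at least 1.1-fold lower number from compound 3 to compound 4 (0.04 log units; that floor lies within the scatter). For compound 4 the estimated value is 90000 nM, with an expected range of 40000 nM to 200000 nM.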

Compound 4, half-maximal inhibitory concentration: 86000 nM
Estimate against measurement, compound 4: 1.0-fold (0.02 log units) above; the range from low to high includes it.
By their numbers in this assay, from the lowest: compound 1; then compounds 2 and 4 (each within the scatter of the next). At a limit, above all of these: compound 3.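

Compound 3 sits at a limit of this assay, not at a number: the limit of > 100000 nM in this assay, at which 1 of the 4 values shown sits.

As far as these compounds go, replacing ethyl with hydrogen at this place on the chain can therefore be read only as a floor, an at least 1.1-fold lower number from compound 3 to compound 4 (0.06 log units; that floor lies within the scatter), and the true size of the chain change stays unknown. With the chain held the same, compound 4 does allow the end groups to be compared: 4-methylpiperazin-1-yl in place of piperidin-1-yl gives a 1.2-fold higher number from compound 2 to compound 4 (0.10 log units; within the scatter), and in place of pyrrolidin-1-yl it gives a 3.0-fold higher number from compound 1 to compound 4 (0.48 log units; beyond the scatter).

From the compounds shown here alone, how a shorter chain such as hexyl would move the number remains open, as does the effect of the pyrrolidin-1-yl or piperidin-1-yl end groups on the longer chain of compound 3. Also open, going by these compounds, is what a morpholine ring or a carboxylic acid at the end group would do.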